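The source may hold more compounds than are shown below. What is called first, only, known or untested is meant among the compounds shown, and "the series" means these compounds.

Three compounds sharing one core have been examined in an ADME assay on HepG2 cells (Homo sapiens) for cytotoxicity, read by sulforhodamine B assay, with a stated time of 48 h; on this read-out higher numbers stand for lower toxicity in this test and lower numbers for higher toxicity in this test. Compound 1 `COc1ccc(-c2nc(/C=C/c3cc4ccccc4nc3OC)no2)cc1` gives only a limit of the assay, > 220000 nM. Compound 2 `COc1nc2ccccc2cc1/C=C/c1noc(-c2ccc(Br)cc2)n1` also gives only a limit, > 195000 nM. Compound 3 `COc1ccccc1-c1nc(/C=C/c2cc3ccccc3nc2OC)no1` again returns a limit rather than a number, > 220000 nM. With all three values being limits, none of the compounds can be placed above or below another.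

The change from compound 1 to compound 2 is bromo in place of methoxy on an aromatic carbon, and the step that the two limits leave unreadable from compound 1 to compound 2 cannot be given a size. The two cores of compound 1 and compound 3 differ as 2-methoxyphenyl in place of 4-methoxyphenyl on an aromatic carbon; the step that the two limits leave unreadable from compound 1 to compound 3 is equally unreadable, as is a step that the two limits leave unreadable from compound 2 to compound 3. What is known rests on the limit of > 195000 nM in this assay, at which 1 of the 3 values shown sits, and on (the limit of > 220000 nM in this assay, at which 2 of the 3 values shown sit).

Compound 4 `COc1nc2ccccc2cc1/C=C/c1noc(-c2ccccc2Br)n1` has not yet been tested. It differs from compound 3 by bromo in place of methoxy on an aromatic carbon. This is the same kind of change as from compound 1 to compound 2, but not the same: there the new group sits para to a large group, here ortho to a large group. The step of an at least 1.1-fold lower number from compound 3 to compound 4 (0.04 log units; that floor lies within the scatter) is expected to be about nothing. This expectation rests on compound 3 having given only a limit, > 220000 nM. It also rests on compound 2 having given only a limit after the same kind of change, > 195000 nM. Compound 4 is therefore expected to give about 200000 nM, somewhere between 100000 nM and 300000 nM, and most likely only a limit.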

Compound 4, half-maximal cytotoxic concentration: > 195000 nM
Compound 4 ended at the assay's limit; the forecaster's own chance of this, stated with the estimate: 85%; the middle value lies beyond the limit too.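

Compound 4, like compound 1, compound 2 and compound 3, returned only a limit of the assay, so no step between any of these compounds can be read. The compounds shown leave open at what concentration any of them becomes toxic to these cells, and whether bromo in place of methoxy, or 2-bromophenyl in place of 4-bromophenyl, changes that concentration at all.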